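The source may hold more compounds than are shown below. What is called first, only, known or untested is meant among the compounds shown, and "the series" means these compounds.

Measured so far in a functional assay on Daoy cells (Homo sapiens) for antiproliferative activity, read by trypan blue exclusion and crystal violet staining, with a stated time of 72 h; on this read-out lower numbers stand for stronger inhibition and higher numbers for weaker inhibition:

- compound 1 `O=C(NC1CCOc2ccccc21)c1cnn2c(C(F)F)cc(C3CC3)nc12`: "not active" (no number reported)
- compound 2 `CC1(C)CC(NC(=O)c2cnn3c(C(F)F)cc(C4CC4)nc23)c2ccccc2O1`: 2300 nM
- compound 3 `O=C(NC1CCCc2ccccc21)c1cnn2c(C(F)(F)F)cc(-c3ccco3)nc12`: 5700 nM

Going by the values given here, only two of these three compounds have a number, and compound 1 was reported as "not active" (no number reported), without one. Of the two numbers, compound 3 has the higher at 5700 nM, so it is the less strongly inhibiting of the pair. Compound 2 gives 2300 nM, and that gap lies beyond the usual scatter of repeat measurements. However, compound 2 differs from compound 3 in more than one place, so the gap says nothing about any single group.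

The next molecule is compound 4 `O=C(NC1CCCc2ccccc21)c1cnn2c(C(F)(F)F)cc(-c3cccs3)nc12`, which keeps everything in compound 3 except one ring: thiophen-2-yl in place of furan-2-yl on an aromatic carbon. Among the compounds with values here, no measured pair here shows a swap of this kind, so the expectation rests on how small the change is and starts from compound 3 at 5700 nM. The estimate means a 1.3-fold lower number from compound 3 to compound 4 (0.10 log units; within the scatter), an expected step towards slightly stronger inhibition that stays within the scatter. There is also some expected chance that no number is obtained, as with compound 1. For compound 4 the expected value is 4500 nM, with an estimated range from 1800 nM to 11000 nM.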

Compound 4, half-maximal inhibitory concentration: 4400 nM
For compound 4 the middle estimate is 1.0-fold (0.01 log units) above the measured one; the measured number falls inside the stated range.
By their numbers in this assay, from the lowest: compounds 2, 4 and 3 (each within the scatter of the next, the first and the last beyond it).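

With thiophen-2-yl in place of furan-2-yl on the aromatic carbon next to the ring nitrogen, this assay gives a 1.3-fold lower number from compound 3 to compound 4 (0.11 log units; within the scatter). This is the first pair shown that differs in one place only, so it gives the first direct reading at this position: a five-membered aromatic ring with one hetero atom can carry either oxygen or sulfur as that hetero atom, and the two compounds cannot be told apart on this read-out. No separate measurement bears on why these two rings read alike.

Still open, on these data alone, is whether a larger or quite different group on this same carbon, such as phenyl, pyridin-2-yl, methyl or an amine, would shift the number beyond the scatter, since both rings compared here have the same size and the same count of hetero atoms. Compounds 1 and 2 differ from compound 3 and compound 4 in more than one place, so the separate roles of cyclopropyl, difluoromethyl and trifluoromethyl on the shared core also remain unread.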